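Acetyl for hydroxyalkyl on the pyrazole chain

The source may hold more compounds than are shown below. What is called first, only, known or untested is meant among the compounds shown, and "the series" means these compounds.

Compound 1: `CCC(=O)c1c(-c2ccccc2)c2cc(Cl)ccc2c(=O)n1Cc1cc(C(N)=O)n(CC)n1`, a physicochemical assay for lipophilicity, at pH 7.4 (a higher number here means a more lipophilic compound, a lower number a more polar compound), 4.08
Compound 2: `CCC(=O)c1c(-c2ccccc2)c2cc(Cl)ccc2c(=O)n1Cc1cc(S(C)(=O)=O)n(CC(N)=O)n1`, 3.42
Compound 3: `CCC(=O)c1c(-c2ccccc2)c2cc(Cl)ccc2c(=O)n1Cc1cc(S(C)(=O)=O)n(CCC(C)(C)O)n1`, 4.23

Compound 3 stands highest of the three measured values; compound 1 is within the scatter of it, while compound 2 lies further off. For the measured compounds named here, the only measured step with one change is a number 0.81 log units higher from compound 2 to compound 3 (beyond the scatter), which replaces a carbamoyl with a hydroxyalkyl group on the same chain carbon.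

Compound 4 is `CCC(=O)c1c(-c2ccccc2)c2cc(Cl)ccc2c(=O)n1Cc1cc(S(C)(=O)=O)n(CC(C)=O)n1`. It differs from compound 3 by acetyl in place of 2-hydroxy-2-methylpropyl on a saturated chain carbon bound to an aromatic nitrogen. The acetyl keeps an acceptor but drops the donor and two carbons, so it sits between the carbamoyl of compound 2 and the hydroxyalkyl of compound 3 in character. The step of a number 0.81 log units higher from compound 2 to compound 3 (beyond the scatter) is the nearest guide, and a move in the downward direction is expected here, beyond the scatter. Compound 4 is therefore estimated at 3.8, with a range from 3.4 to 4.2, a step of a number 0.43 log units lower from compound 3 to compound 4 (beyond the scatter) that is expected rather than measured.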

Compound 4, distribution coefficient: 3.79
Compound 4: middle estimate off by 0.01 log units, on the high side; the measured number falls inside the stated range.
By their numbers in this assay, from the lowest: compound 2; then compounds 4, 1 and 3 (each within the scatter of the next, the first and the last beyond it).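

On a saturated chain carbon bound to an aromatic nitrogen, acetyl in place of 2-hydroxy-2-methylpropyl gives a number 0.44 log units lower from compound 3 to compound 4 (beyond the scatter) in this assay, while methyl in place of amino on a carbonyl carbon gives a number 0.37 log units higher from compound 2 to compound 4 (beyond the scatter). The second step shows that exchanging amino for methyl on that carbonyl carbon, with the rest of the compound unchanged, is enough to shift the number beyond the scatter, and together the steps separate the three groups at this place, with compound 4 above compound 2 and below compound 3. Nothing shown gives a reason for either step.

The compounds shown leave open how an amine or a carboxylic acid on this chain would read. They also leave open whether a longer chain carrying the same acetyl would stay near compound 4 or move towards compound 3.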